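Swapping hydroxy for amino on two related oxazolone cores

The source may hold more compounds than are shown below. What is called first, only, known or untested is meant among the compounds shown, and "the series" means these compounds.

The series rests on two closely related cores. Compound 1 `COc1ccc(-c2coc(=O)n2-c2cc(OC)c(OC)c(OC)c2)cc1O` carries a hydroxy group on a six-membered aromatic ring and, in a functional assay on PC-3 cells (Homo sapiens) for inhibition (on this read-out higher numbers stand for weaker inhibition and lower numbers for stronger inhibition), compound 1 gives 2.3 nM. Compound 2 `COc1ccc(-c2coc(=O)n2-c2cc(OC)c(OC)c(OC)c2)cc1N` differs from it only as follows: amino in place of hydroxy on an aromatic carbon. In this assay compound 2 gives 2.5 nM, so the step of a 1.1-fold higher number from compound 1 to compound 2 (0.04 log units; within the scatter) is a flat one. Compound 3 `COc1ccc(-c2oc(O)nc2-c2cc(OC)c(OC)c(OC)c2)cc1O` shares the same atoms as compound 1 joined differently; the difference between the two cores is not broken down here. In this assay compound 3 gives 6.4 nM, the highest of the three numbers and beyond the scatter from both compound 1 and compound 2.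

Compound 4 `COc1ccc(-c2oc(O)nc2-c2cc(OC)c(OC)c(OC)c2)cc1N` is not yet measured. It stands to compound 3 as compound 2 stands to compound 1: amino in place of hydroxy on an aromatic carbon. The place of the change is the same in both pairs, so this is the same change. Because the step of a 1.1-fold higher number from compound 1 to compound 2 (0.04 log units; within the scatter) stayed within the scatter, the step from compound 3 to compound 4 is expected to be similarly small, a 1.1-fold higher number from compound 3 to compound 4 (0.04 log units; within the scatter). In this assay compound 4 is accordingly estimated at 7 nM, with a likely range from 3.5 nM to 14 nM.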

Compound 4, half-maximal inhibitory concentration: 2.1 nM
Estimate against measurement, compound 4: 3.3-fold (0.52 log units) above; measured number below the stated range.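

On the core of compound 3, in this assay, amino in place of hydroxy gives a 3.0-fold lower number from compound 3 to compound 4 (0.48 log units; beyond the scatter), whereas on the core of compound 1 the same change gives a 1.1-fold higher number from compound 1 to compound 2 (0.04 log units; within the scatter). The result of this change therefore did not carry over unchanged from one core to the other: the same change on two cores in this assay, a 1.1-fold higher number (0.04 log units; within the scatter) from compound 1 to compound 2 and a 3.0-fold lower number (0.48 log units; beyond the scatter) from compound 3 to compound 4, 3.3-fold (0.52 log units) apart, beyond the scatter of two such steps. This shows that a flat step on one core need not stay flat on the closely related one, but it does not show why the two steps differ, and with a single pair on each core it sets no rule for the series.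

The compounds shown leave open whether other groups in the same place, such as a methylamino group, an acetamido group or a fluorine atom, would also behave differently on the two cores. They also leave open whether a change elsewhere, such as an ethoxy group in place of the methoxy group on the same ring, would show such a gap between the cores.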